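Paw edema series: aryl variation on the saturated ring carbon

The compounds below may be only part of what the source reports. "The series", "measured", "known", "first", "only" and "open" are said of these compounds alone.

In a functional assay on the whole organism for inhibition, with Rattus norvegicus as the target, read by paw edema, with stated times of 30 min and 3 h, at a dose of 10 mg/kg by the oral route (on this read-out lower numbers stand for less inhibition and higher numbers for more inhibition at the one dose given (going by the name of the read-out)), the measured compounds stand as follows:
compound 1, `O=C1N=C(C2C(=O)c3ccccc3C2=O)CC(c2ccccc2[N+](=O)[O-])N1`: 26%
compound 2, `O=C1N=C(C2C(=O)c3ccccc3C2=O)CC(c2cccc([N+](=O)[O-])c2)N1`: 21%
compound 3, `O=C1N=C(C2C(=O)c3ccccc3C2=O)CC(c2ccc(Cl)cc2)N1`: 31%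

Compound 3 holds the highest of the three numbers, yet the steps of a number 5 percentage points higher from compound 1 to compound 3 (within the scatter) and a number 10 percentage points higher from compound 2 to compound 3 (within the scatter) are both within the scatter, as is a number 5 percentage points lower from compound 1 to compound 2 (within the scatter), so none of the three is set apart from the others. Compound 4 `CN(C)c1ccc(C2CC(C3C(=O)c4ccccc4C3=O)=NC(=O)N2)cc1` differs from compound 3 by dimethylamino in place of chloro on an aromatic carbon. For the measured compounds named here, no measured step involves the dimethylamino group, and every measured step, each an exchange of the aryl group on the saturated ring carbon, stayed within the scatter; on that basis a step of a number 3 percentage points lower from compound 3 to compound 4 (within the scatter) is expected, none beyond the scatter. Compound 4 is therefore estimated at 28%, within a range from 14% to 42%.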

Compound 4, a percentage reported as inhibition, in the whole organism at one dose (the size of the read-out at that dose, not a potency): 20%
Compound 4: the middle estimate sits 8 percentage points above what was measured; the range from low to high includes it.
By their numbers in this assay, from the lowest: compounds 4, 2, 1 and 3 (each within the scatter of the next, the first and the last beyond it).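

In this assay, for the compounds shown here, the step of a number 11 percentage points lower from compound 3 to compound 4 (beyond the scatter) is the first to pass the scatter, and it is set at the aromatic carbon that carries the chloro or dimethylamino group. Set against the two nitrophenyl compounds, the steps of a number 1 percentage points lower from compound 2 to compound 4 (within the scatter) and a number 6 percentage points lower from compound 1 to compound 4 (within the scatter) separate nothing, so only compound 3 and compound 4 stand apart. No measured evidence on hand accounts for the step.

As far as these compounds go, whether an amine or a carboxylic acid on that aromatic carbon would read nearer compound 3 or compound 4 stays open. So does whether the gap holds at other doses.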